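A few compounds are considered here, and "the series" means these few. Any claim that something is new, unique, unknown or untested is made for them only; others in the source may bear on it.

Within the data shown here, in an in vitro ADME assay on microsomes from liver (Homo sapiens) for metabolic stability (a higher number here means faster removal of the compound, a lower number slower removal), compound 1 (`COCc1nc2nc(C)cc(Nc3ccc(C(F)(F)F)cc3)n2n1`) gives 6.7 mL.min-1.g-1, the lower of the two numbers so far, well under compound 2 (`Cc1cc(Nc2cccc(Cl)c2)n2nc(C(C)(F)F)nc2n1`) at 44.4 mL.min-1.g-1. Compound 3 (`Cc1cc(Nc2ccc(C(F)(F)F)cc2)n2nc(C3CC3)nc2n1`) has cyclopropyl in place of methoxymethyl on an aromatic carbon, and is otherwise the same as compound 1 (cyclopropyl in place of methoxymethyl on an aromatic carbon). Among the measured compounds shown here, no measured pair shows this swap, so the estimate is uncertain. The expected change is a small rise that stays within the scatter, with an estimated step of a 1.5-fold higher number from compound 1 to compound 3 (0.17 log units; within the scatter). For compound 3 the expected value is 10 mL.min-1.g-1, with an estimated range of 4 mL.min-1.g-1 to 25 mL.min-1.g-1.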

Compound 3, intrinsic clearance in microsomes: < 5 mL.min-1.g-1
Compound 3: only a limit was reported; the forecaster's own chance of this, stated with the estimate: 3%; at least 2.0-fold (0.30 log units) between middle value and limit.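

Among these compounds, at this position, on an aromatic carbon of the five-membered ring, the swap from methoxymethyl to cyclopropyl gives the first step in this assay, which is an at least 1.3-fold lower number from compound 1 to compound 3 (0.12 log units; that floor lies within the scatter). The ring without oxygen therefore keeps removal slow in this pair, so the oxygen of methoxymethyl is not needed for that here. The value of compound 3 is a limit and not a number, so only a floor for the step can be read: the limit of < 5 mL.min-1.g-1 in this assay, at which 1 of the 3 values shown sits.

On these data alone, whether an amine or a longer carbon chain on this same carbon would also keep removal slow stays open. As far as these compounds go, how far the true value of compound 3 lies under its limit also stays open.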